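The compounds below may be only part of what the source reports. "The series", "measured", "known", "first", "only" and "open" are said of these compounds alone.

Measured so far:
- compound 1 `CCCN(CCC)c1nc(Cc2c(F)cccc2F)c(C)c(=O)[nH]1`: > 74000 nM (a limit)
- compound 2 `Cc1c(Cc2c(F)cccc2F)nc(N2CCC(C)CC2)[nH]c1=O`: > 75000 nM (a limit)

Both readings come from an ADME assay on MT4 cells (Homo sapiens) for cytotoxicity, read by MTT assay, with a stated time of 4 days; on this read-out higher numbers stand for lower toxicity in this test and lower numbers for higher toxicity in this test. Compound 2 stands only at a limit, > 75000 nM, and gives no number. Compound 1 also gives only a limit, > 74000 nM. The next change leads to compound 3 `Cc1c(Cc2c(F)cccc2F)nc(N2CCN(C)CC2)[nH]c1=O`, with 4-methylpiperazin-1-yl in place of 4-methylpiperidin-1-yl on the same aromatic carbon: 4-methylpiperazin-1-yl in place of 4-methylpiperidin-1-yl on an aromatic carbon. Among the measured compounds shown here, the one measured step at this carbon bears on it, but it gives no size: a step that the two limits leave unreadable from compound 1 to compound 2. With no size to carry over, no step beyond the scatter is expected in this assay, and a further limit is the likeliest report. The expected step is a number no higher from compound 2 to compound 3 (the limit leaves the size open). The estimate for compound 3 is 75000 nM, with an expected range of 30000 nM to 150000 nM.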

Compound 3, half-maximal cytotoxic concentration: > 75000 nM
Compound 3 was reported as a limit (the forecaster's own chance of this, stated with the estimate: 75%); the middle value lies on the limit itself.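

Among the compounds shown here, compound 3 gives > 75000 nM in this assay, a limit and not a number, so no step among compound 1, compound 2 and compound 3 can be read. From the compounds shown here alone, whether these three compounds differ at all in this assay stays open.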